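Sulfonate Ester to Sulfonanilide on the Iodoquinoline Core

This account rests on a few compounds, and the source may have more. Where it says the series, first, only, none or still open, it means among the compounds named here.

Compound 2 `CCCCCOS(=O)(=O)c1ccc(F)c2ncc(I)cc12` is recorded in an assay for inhibition of methylcytosine dioxygenase TET2 (Homo sapiens), read by mass spectrometry, with stated times of 30 min and 1 h (on this read-out lower numbers stand for stronger inhibition and higher numbers for weaker inhibition), only as a limit, > 200000 nM. It therefore stands at the limit of > 200000 nM in this assay, at which 1 of the 2 values shown sits. For the measured compounds named here, compound 1 `O=S(=O)(O)c1ccc(F)c2ncc(I)cc12` gives 2300 nM in this assay, and the single measured step, an at least 86-fold higher number from compound 1 to compound 2 (1.93 log units; beyond the scatter), pentyl in place of hydrogen on an oxygen, is large. Compound 3 `O=S(=O)(Nc1ccccc1)c1ccc(F)c2ncc(I)cc12` carries anilino in place of pentyloxy on a sulfonyl sulfur. Going by the values given here, no measured step covers anilino directly; what is known is only that replacing the hydrogen on the oxygen, as in an at least 86-fold higher number from compound 1 to compound 2 (1.93 log units; beyond the scatter), removed measurable inhibition, and compound 3 likewise lacks that hydrogen. Compound 3 is therefore expected to remain weak, estimated at 60000 nM, range 10000 nM to 200000 nM, an expected step of an at least 3.3-fold lower number from compound 2 to compound 3 (0.52 log units; beyond the scatter).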

Compound 3, half-maximal inhibitory concentration: 23900 nM
Compound 3: the middle estimate sits 2.5-fold (0.40 log units) above what was measured; the range from low to high includes it.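

In this assay, a group other than hydroxy on the sulfonyl sulfur can keep measurable inhibition: anilino in place of pentyloxy gives an at least 8.3-fold lower number from compound 2 to compound 3 (0.92 log units; beyond the scatter). Compound 2 enters that step only as a limit: the limit of > 200000 nM in this assay, at which 1 of the 3 values shown sits. Anilino in place of hydroxy still gives a 10-fold higher number from compound 1 to compound 3 (1.02 log units; beyond the scatter), leaving compound 1 the strongest of the three.

The compounds shown do not separate the contribution of the aromatic ring from that of the hydrogen on the anilino nitrogen. Going by these compounds, how a plain amino group, a cyclohexylamino group or a methylated anilino group on the sulfonyl sulfur would read remains open.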